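The compounds below may be only part of what the source reports. "The series", "measured", "known", "first", "only" and "open" are said of these compounds alone.

Series notes. Compound 1 `CCn1cc(-c2ccnc(Nc3ccc(OC)cc3OC)n2)c2ccccc21` and compound 2 `COc1ccc(Nc2nccc(-c3cn(C)c4ccccc34)n2)c(OC)c1` share one core; compound 3 `CCCSc1nc(C)c(-c2ccnc(Nc3ccc(OC)cc3OC)n2)s1` and compound 4 `CCSc1nc(C)c(-c2ccnc(Nc3ccc(OC)cc3OC)n2)s1` share another, and the difference between the two cores is not broken down here. All measured members were run in a functional assay on MV4-11 cells (Homo sapiens) for inhibition, read by resazurin assay, with a stated time of 72 h; on this read-out higher numbers stand for weaker inhibition of growth and lower numbers for stronger inhibition of growth. Compound 1 gives 3590 nM, compound 2 gives 3410 nM and compound 3 gives 2240 nM; the three numbers sit within the scatter of one another, so no order among them is claimed.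

Compound 2 differs from compound 1 by hydrogen in place of methyl on a saturated chain carbon bound to an aromatic nitrogen, and this step reads a 1.1-fold lower number from compound 1 to compound 2 (0.02 log units; within the scatter). Compound 4 differs from compound 3 by hydrogen in place of methyl on a saturated chain carbon, two bonds along the chain from a sulfur. This is the same kind of change as that between compound 1 and compound 2, though the surroundings of the place differ: in the first pair the carbon is bound to an aromatic nitrogen, in the second it is two bonds along the chain from a sulfur. Because a 1.1-fold lower number from compound 1 to compound 2 (0.02 log units; within the scatter) was small, a similarly small step is expected in this assay, a 1.0-fold higher number from compound 3 to compound 4 (0.01 log units; within the scatter). For the measured compounds named here, with only one prior example of the change, on a different core, this expectation is loosely held. Compound 4 is thus estimated at 2300 nM, with a range from 1100 nM to 4800 nM.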

Compound 4, concentration for 50% growth inhibition: 32400 nM
Compound 4: middle estimate off by 14-fold (1.15 log units), on the low side, and the stated range ends below it.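

In this assay, the change from propylsulfanyl to ethylsulfanyl reads a 14-fold higher number from compound 3 to compound 4 (1.16 log units; beyond the scatter). The same change does not carry over unchanged from one core to the other in this series: the same change on two cores in this assay, a 1.1-fold lower number (0.02 log units; within the scatter) from compound 1 to compound 2 and a 14-fold higher number (1.16 log units; beyond the scatter) from compound 3 to compound 4, 15-fold (1.18 log units) apart, beyond the scatter of two such steps

For the compounds shown here, with a single pair on each core, this shows only that a small step on the core of compound 1 did not predict the step on the core of compound 3; it does not show whether the gap belongs to the cores themselves, to a chain on sulfur as against a chain on an aromatic nitrogen, or to both.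

Left open is how the number moves along the sulfur chain beyond these two members, for instance with methylsulfanyl or butylsulfanyl, and whether a propyl chain on the aromatic nitrogen of the core of compound 1 would give a large step. Also open, as far as these compounds go, is whether a chain carrying an amine in place of propylsulfanyl would read like compound 3 or like compound 4.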